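Defined configuration at the ring carbon of compound 3

The compounds below may be only part of what the source reports. "The series", "measured", "known", "first", "only" and "open" are said of these compounds alone.

Compound 3 `Cc1cccc(/N=C/C2=C3NC=C(C(=O)O)C(=O)N3C(C)CC2)c1` stands lowest of the three numbers in a functional assay on the whole organism with Rattus norvegicus as the target (on this read-out higher numbers stand for an effect only at larger amounts of compound and lower numbers for an effect already at smaller amounts), where compound 3 gives 0.8 umol/kg. Compound 1 `CC1CCC(/C=N/c2ccccc2F)=C2NC=C(C(=O)O)C(=O)N21` gives 14.5 umol/kg and compound 2 `CC1CCC(/C=N/c2ccc(F)cc2)=C2NC=C(C(=O)O)C(=O)N21` gives 10.6 umol/kg; the steps of an 18-fold lower number from compound 1 to compound 3 (1.26 log units; beyond the scatter) and a 13-fold lower number from compound 2 to compound 3 (1.12 log units; beyond the scatter) are both beyond the scatter, whereas a 1.4-fold lower number from compound 1 to compound 2 (0.14 log units; within the scatter) is within it. Compound 4 `Cc1cccc(/N=C/C2=C3NC=C(C(=O)O)C(=O)N3[C@@H](C)CC2)c1` differs from compound 3 only in that (the two compounds have the same atoms and bonds; at least one stereo element is drawn with a configuration in one of them and without one in the other: 1 of 2 stereo elements differ; a stereocentre at a saturated ring carbon is drawn without a configuration in compound 3 and S in compound 4). Among the compounds with values here, none of the measured steps bears on this: all three change the group on the double-bonded nitrogen and leave the ring carbon undrawn, so they give no guide to the size or direction of the step. If the drawn configuration carries the activity seen in compound 3, a somewhat lower number is expected for compound 4; if not, a considerably higher one. Weighing both, compound 4 is expected to give about 0.7 umol/kg in this assay. The range for compound 4 is estimated as 0.3 umol/kg to 3 umol/kg. This means an expected step of a 1.1-fold lower number from compound 3 to compound 4 (0.06 log units; within the scatter) for compound 4.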

Compound 4, dose for 50% inhibition: 0.02 umol/kg
Compound 4: the middle estimate sits 35-fold (1.54 log units) above what was measured, outside the stated range (below it).
By their numbers in this assay, from the lowest: compound 4; then compound 3; then compounds 2 and 1 (each within the scatter of the next).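

Defining the saturated ring carbon as S, with atoms and bonds unchanged, gives in this assay a 40-fold lower number from compound 3 to compound 4 (1.60 log units; beyond the scatter). This stereocentre therefore moves the number beyond the scatter, which until now had been shown only for changes to the group on the double-bonded nitrogen. The step can be tied only to the stereocentre: the fact that one of compounds 3 and 4 is drawn with a defined configuration and the other without, at the place where they differ.

Open, going by these compounds, is how the R form at this ring carbon reads, and whether an ethyl group or a longer chain there in place of the methyl keeps the low number. Also open, on these data alone, is whether the S form gives a comparable step with the 2-fluorophenyl and 4-fluorophenyl groups on the double-bonded nitrogen.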